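Trimming the Oxime Substituent of Compound 1

This account rests on a few compounds, and the source may have more. Where it says the series, first, only, none or still open, it means among the compounds named here.

Of the compounds shown here, two have been measured in a functional assay (blood) for inhibition, with Homo sapiens as the target; a higher number here means a weaker inhibitor, a lower number a stronger inhibitor. Compound 1 `COC(=O)c1cc(CO/N=C(\C)c2ccc(Sc3cc(F)cc(C4CCOCC4)c3)cc2)on1` gives 100 nM in this assay. Compound 2 `COC1(c2csc(Sc3ccc4c(c3)CC/C4=N\O)c2)CCOCC1` shares no single-point relationship with compound 1. In this assay compound 2 gives 130 nM. Going by the values given here, the two numbers lie within the usual scatter of one another, so compound 1 cannot be set apart from compound 2 on the present data, and no step between measured compounds is available as a guide.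

Compound 3 `CC(=O)O/N=C(\C)c1ccc(Sc2cc(F)cc(C3CCOCC3)c2)cc1` has not yet been measured. It differs from compound 1 in one place: acetyl in place of (3-(methoxycarbonyl)-1,2-oxazol-5-yl)methyl on an oxygen. A sizeable group with an aromatic ring and several acceptors is exchanged for a small acetyl, so a step beyond the scatter is plausible, and the expectation is for a weaker inhibitor rather than a stronger one. The expected step from compound 1 to compound 3 is a 2.5-fold higher number from compound 1 to compound 3 (0.40 log units; beyond the scatter). The estimate for compound 3 in this assay is 250 nM, with a range from 80 nM to 800 nM.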

Compound 3, half-maximal inhibitory concentration: 50 nM
Compound 3: middle estimate off by 5.0-fold (0.70 log units), on the high side; the measured number lies below the stated range.
By their numbers in this assay, from the lowest: compounds 3, 1 and 2 (each within the scatter of the next, the first and the last beyond it).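

Exchanging (3-(methoxycarbonyl)-1,2-oxazol-5-yl)methyl for acetyl, on the oxygen whose other neighbour is the double-bonded nitrogen, gives a 2.0-fold lower number from compound 1 to compound 3 (0.30 log units; within the scatter) in this assay. Going by these compounds alone, this is the first step here between compounds that differ in one place, and it shows that the five-membered aromatic ring and the rest of the larger group can leave this oxygen without a change that rises beyond the scatter, so compound 3 and compound 1 cannot be ranked against each other, and the larger group shows no measurable advantage over acetyl in this comparison. No supporting data are at hand that would account for this result.

What the compounds shown leave open is how far this tolerance extends, since a single exchange cannot tell whether the carbonyl of the acetyl matters or whether a plain methyl, a longer chain, a carboxylic acid or an amine on the same oxygen would give a number close to those of compound 1 and compound 3. Going by these compounds, it also remains open whether the same exchange would behave alike on the core of compound 2, which differs from compound 1 in more than one place.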